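A few compounds are considered here, and "the series" means these few. Any claim that something is new, unique, unknown or untested is made for them only; others in the source may bear on it.

Compound 1 `CN(C)c1ccc(C(=O)Nc2cccc(NC(=O)COc3ccc4c(c3)CCC(=O)N4)c2)cc1` — in an assay on isolated protein for inhibition of Rho-associated protein kinase 1 (Homo sapiens), read by scintillation counting, radiometric assay and 33P incorporation, with a stated time of 40 min, in the presence of a further agent that is not named here (on this read-out lower numbers stand for stronger inhibition and higher numbers for weaker inhibition), compound 1 gives > 10000 nM
Compound 2 `COc1cc(OCC(=O)Nc2cccc(NC(=O)c3ccc(N(C)C)cc3)c2)ccc1C=O` — in this assay compound 2 gives 3740 nM
Compound 3 `CC(=O)Nc1cccc(NC(=O)COc2ccc3c(=O)ccoc3c2)c1` — in this assay compound 3 gives 2500 nM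

The number recorded for compound 1 is a limit of the assay, not a measured value. Among the numbers that are actual measurements, compound 3 stands lowest, and compound 2 sits a short way from it, within the usual scatter, so the two cannot be ordered. For the measured compounds named here, the single step between measured compounds, an at least 2.6-fold lower number from compound 1 to compound 2 (0.42 log units; beyond the scatter), concerns the group on the oxygen on a saturated carbon and rests on the limit (the limit of > 10000 nM in this assay, at which 1 of the 3 values shown sits).

Compound 4 `Cc1ccc(C(=O)Nc2cccc(NC(=O)COc3ccc4c(=O)ccoc4c3)c2)cc1` differs from compound 3 in one place: 4-methylphenyl in place of methyl on a carbonyl carbon. Going by the values given here, no measured step touches this position; compound 2, which carries a six-membered aromatic ring of carbon only on the same carbonyl carbon, differs from compound 3 in the ether group as well, so its value shows only what the two numbers show together, a gap within the scatter. The expectation for compound 4 therefore rests on the read-out of compound 3 alone, with wide uncertainty. Compound 4 is estimated at 1200 nM, between 300 nM and 5000 nM, which corresponds to an expected 2.1-fold lower number from compound 3 to compound 4 (0.32 log units; beyond the scatter).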

Compound 4, half-maximal inhibitory concentration: 183 nM
Compound 4: the middle estimate sits 6.6-fold (0.82 log units) above what was measured, outside the stated range (below it).
By their numbers in this assay, from the lowest: compound 4; then compounds 3 and 2 (each within the scatter of the next). At a limit, above all of these: compound 1.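

Setting 4-methylphenyl in place of methyl on a carbonyl carbon gives a 14-fold lower number from compound 3 to compound 4 (1.14 log units; beyond the scatter) in this assay, a large step and the first one shown at this position. The earlier compounds shown here offered no step here, so only now is it clear that the number in this assay depends strongly on what sits on this carbonyl carbon, and that the larger group with its aromatic ring is accepted there and goes with a much lower number. Nothing measured here accounts for the size of this step, which so far rests on a single pair of compounds.

For the compounds shown here, with only this one pair, it remains open whether the lower number goes with the six-membered aromatic ring itself or depends on its methyl, and whether a plain phenyl, or a phenyl carrying an amine or a carboxylic acid, would give a similar number. Also open, going by these compounds, is whether a longer chain without a ring would move the number at all, and whether the same step would hold with a different group on the oxygen on a saturated carbon.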